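A few compounds are considered here, and "the series" means these few. Any claim that something is new, unique, unknown or untested is made for them only; others in the source may bear on it.

Working notes on the series in a functional assay on U-251 cells (Homo sapiens) for inhibition, read by sulforhodamine B assay, with a stated time of 48 h; a higher number here means a weaker inhibitor of growth, a lower number a stronger inhibitor of growth. Compound 1 (`Cc1ccc(C2=NN(c3ccc(S(C)(=O)=O)cc3)C(=O)CC2)cc1`) gives 450 nM, and compound 2 (`Cc1cc(O)ccc1C1=NN(c2ccc(S(C)(=O)=O)cc2)C(=O)CC1`) gives 4300 nM, the higher of the two numbers. Compound 3 (`CCc1ccc(C2=NN(c3ccc(S(C)(=O)=O)cc3)C(=O)CC2)cc1`) has 4-ethylphenyl in place of 4-hydroxy-2-methylphenyl on a carbon with a double bond to nitrogen. Among the measured compounds shown here, the only measured step bearing on this is a 9.6-fold higher number from compound 1 to compound 2 (0.98 log units; beyond the scatter), which is beyond the scatter. Since 4-ethylphenyl resembles the 4-methylphenyl of compound 1, that step is expected to largely reverse. The expected step is an 8.6-fold lower number from compound 2 to compound 3 (0.93 log units; beyond the scatter). For compound 3 the estimated value is 500 nM, with a range of 180 nM to 1400 nM.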

Compound 3, concentration for 50% growth inhibition: 1910 nM
Estimate against measurement, compound 3: 3.8-fold (0.58 log units) below, outside the stated range (above it).
By their numbers in this assay, from the lowest: compound 1; then compound 3; then compound 2.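

Going from 4-methylphenyl to 4-ethylphenyl at this place is not a neutral change: the single added methyl gives a 4.2-fold higher number from compound 1 to compound 3 (0.63 log units; beyond the scatter). The step of a 2.3-fold lower number from compound 2 to compound 3 (0.35 log units; beyond the scatter) shows that 4-ethylphenyl recovers only part of the difference between the other two groups, leaving compound 3 between compound 1 and compound 2. Nothing available gives a reason for either step.

From the compounds shown here alone, whether a longer chain such as propyl raises the number further remains open. So does how much of the weaker result of compound 2 belongs to its hydroxyl and how much to its 2-methyl.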